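The source may hold more compounds than are shown below. What is called first, only, known or untested is meant among the compounds shown, and "the series" means these compounds.

Working notes on the series. Compound 1 (`O=C(O)C[C@H]1CC[C@H](c2ccc(C(=O)Nc3nnc(Cc4ccc(F)cc4)o3)cc2)CC1`) gives < 2000 nM in a physicochemical assay for solubility, read by HPLC, with a stated time of 20 h, at pH 1 (a higher number here means a more soluble compound, a lower number a less soluble compound), as a limit and not a number. Compound 2 (`O=C(O)C[C@H]1CC[C@H](c2ccc(C(=O)Nc3noc(Cc4ccccc4)n3)cc2)CC1`) gives < 2000 nM as a limit too. Compound 3 (`NC(=O)C[C@H]1CC[C@H](c2ccc(C(=O)Nc3nnc(Cc4ccccc4)s3)cc2)CC1`) stands at < 2000 nM as a limit as well, with no number of its own. The set so far reads as a single floor (the limit of < 2000 nM in this assay, at which 3 of the 3 values shown sit) and gives no order among these compounds. Within the data shown here, no two of them differ in one place, so no measured step is available to size the next change.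

Compound 4 (`CN(C)CCNC(=O)C[C@H]1CC[C@H](c2ccc(C(=O)Nc3nnc(Cc4ccccc4)s3)cc2)CC1`) is compound 3 with 2-(dimethylamino)ethyl in place of hydrogen on an amide-type nitrogen. The chain that enters carries no net charge as counted, and the change sits on the carbamoylmethyl end of the molecule. The expectation starts from compound 3 at < 2000 nM as a limit, so it rests on the structural change alone and is loosely anchored. The expected size is an at least 20-fold higher number from compound 3 to compound 4 (1.30 log units; beyond the scatter) as an estimate, upward in this assay and beyond the scatter. Compound 4 is estimated at 40000 nM with 3000 nM to 500000 nM as the expected range.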

Compound 4, solubility: 6000 nM
Compound 4: the middle estimate sits 6.7-fold (0.82 log units) above what was measured; the range from low to high includes it.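

Among these compounds, the carbamoylmethyl end of the molecule is the first place where a single change lifts the read-out off the floor: 2-(dimethylamino)ethyl in place of hydrogen on the amide-type nitrogen gives an at least 3.0-fold higher number from compound 3 to compound 4 (0.47 log units; beyond the scatter) in this assay and so provides the first step that can be sized, with compound 4 also the first compound to carry a number of its own. Compound 3 gives < 2000 nM in this assay as a limit and not a number. Going by these compounds, the step therefore fixes only the smallest size the change can have, and its true size stays unknown because the starting point lies at this floor: the limit of < 2000 nM in this assay, at which 3 of the 4 values shown sit.

The compounds shown leave open whether the terminal dimethylamino group is what matters or whether the chain alone would do, which a 2-hydroxyethyl group, a 2-methoxyethyl group or a longer chain ending in the same amine at this nitrogen would separate. They also leave open whether a cyclic amine such as morpholine or piperazine on the same chain would move the read-out further, and whether the change carries over to the cores of compound 1 and compound 2.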